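Halogen swap on the benzoxazole: fluoro to chloro

The source may hold more compounds than are shown below. What is called first, only, known or untested is meant among the compounds shown, and "the series" means these compounds.

Measured compounds, cytotoxicity on HT-29 cells:
- compound 1 `Cc1ccc2oc(-c3ccc(NC(=O)CN4CCN(CCCN(C)C)CC4)cc3)nc2c1`: 3890 nM
- compound 2 `CN(C)CCN1CCN(CC(=O)Nc2ccc(-c3nc4cc(Cl)ccc4o3)cc2)CC1`: 4470 nM
- compound 3 `CN(C)CCCN1CCN(CC(=O)Nc2ccc(-c3nc4cc(F)ccc4o3)cc2)CC1`: 2590 nM

In a functional assay on HT-29 cells (Homo sapiens) for cytotoxicity, read by MTT assay, with a stated time of 24 h (a higher number here means a weaker inhibitor, a lower number a stronger inhibitor), compound 3 gives the lowest of the three numbers, but its separations from compound 1 and from compound 2 are both within the scatter, so the three compounds cannot be ordered on these data.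

Compound 4 `CN(C)CCCN1CCN(CC(=O)Nc2ccc(-c3nc4cc(Cl)ccc4o3)cc2)CC1` differs from compound 3 in one place: chloro in place of fluoro on an aromatic carbon. Cut one bond further out, the change reads 5-fluoro-1,3-benzoxazol-2-yl to 5-chloro-1,3-benzoxazol-2-yl.

Among the compounds with values here, only one single-point step is available, a 1.5-fold lower number from compound 1 to compound 3 (0.18 log units; within the scatter), and it concerns a methyl, not a chloro. Within the data shown here, compound 2 carries the chloro but also a shorter chain on the piperazine, so no step to compound 3 is given; its value and that of compound 3 lie within the scatter of each other. Nothing here suggests that the halogen swap moves the number beyond the scatter.

Compound 4 is therefore expected to sit close to compound 3, with an estimated step of a 1.2-fold higher number from compound 3 to compound 4 (0.06 log units; within the scatter). The estimate for compound 4 is 3000 nM, with a range from 1500 nM to 6000 nM.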

Compound 4, half-maximal inhibitory concentration: 1640 nM
Beside the measured number, compound 4's estimate is 1.8-fold (0.26 log units) above it; measured number inside the range.
By their numbers in this assay, from the lowest: compounds 4, 3, 1 and 2 (each within the scatter of the next, the first and the last beyond it).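

In this assay the change from 5-fluoro-1,3-benzoxazol-2-yl to 5-chloro-1,3-benzoxazol-2-yl gives a 1.6-fold lower number from compound 3 to compound 4 (0.20 log units; within the scatter) and so does not separate the two halogens at this position on these data. Within the data shown here, compound 4 nevertheless gives the first single-place steps beyond the scatter: chloro in place of methyl on this aromatic carbon gives a 2.4-fold lower number from compound 1 to compound 4 (0.38 log units; beyond the scatter) and, with chloro held fixed, (dimethylamino)methyl in place of dimethylamino on the saturated chain gives a 2.7-fold lower number from compound 2 to compound 4 (0.44 log units; beyond the scatter) as a second modest step. The data at hand offer no explanation for either modest step.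

From the compounds shown here alone, whether a bromo, a methoxy or a trifluoromethyl group at this aromatic carbon would move the number beyond the scatter from the chloro of compound 4 remains open. Also open, going by these compounds, are whether a longer chain on the piperazine would extend the step seen with the chain change, and whether that chain step would recur with fluoro or methyl in place of chloro.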